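Swapping a halogen on the aniline ring: compound 3 expected

A few compounds are considered here, and "the series" means these few. Any claim that something is new, unique, unknown or untested is made for them only; others in the source may bear on it.

Compound 2 `Cc1ccc(S(=O)(=O)/N=C(/CCNC2=CC(=O)c3ccccc3C2=O)Nc2ccc(Cl)cc2)cc1` was tested in an ADME assay on HEK293 cells (Homo sapiens) for cytotoxicity, read by MTT assay, with a stated time of 48 h (on this read-out lower numbers stand for stronger inhibition and higher numbers for weaker inhibition), and gives 65400 nM. Going by the values given here, only one other compound has a number here: compound 1 `COc1ccc(N/C(CCNC2=CC(=O)c3ccccc3C2=O)=N\S(=O)(=O)c2ccc(C)cc2)cc1`, which gives 35100 nM. Among the compounds with values here, on these two numbers compound 2 stands higher, but the one measured step, a 1.9-fold higher number from compound 1 to compound 2 (0.27 log units; within the scatter), is too small to count as a real difference, so the two compounds cannot be ranked against each other.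

Compound 3 `Cc1ccc(S(=O)(=O)/N=C(/CCNC2=CC(=O)c3ccccc3C2=O)Nc2ccc(F)cc2)cc1` has not yet been measured. The change from compound 2 to compound 3 is fluoro in place of chloro on an aromatic carbon — in longer words, a (4-chlorophenyl)amino group becomes a (4-fluorophenyl)amino group. Within the data shown here, no measured step exchanges one halogen for another. Among the measured compounds shown here, the only step available, a 1.9-fold higher number from compound 1 to compound 2 (0.27 log units; within the scatter), changes the same ring position from methoxy to chloro and stays within the scatter, which is the closest guide to how much this position matters on the shared core.

Because a 1.9-fold higher number from compound 1 to compound 2 (0.27 log units; within the scatter) is within the scatter, compound 3 is expected to show a step of a 1.2-fold lower number from compound 2 to compound 3 (0.08 log units; within the scatter) in this assay, that is, no change beyond the scatter. Compound 3 is therefore estimated at 55000 nM, with a range from 25000 nM to 120000 nM.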

Compound 3, half-maximal inhibitory concentration: 55100 nM
Compound 3: the middle estimate sits 1.0-fold (0.00 log units) below what was measured; measured number inside the range.
By their numbers in this assay, from the lowest: compounds 1, 3 and 2 (each within the scatter of the next).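

In this assay, exchanging one halogen for the other on this aromatic carbon gives a step (a 1.2-fold lower number from compound 2 to compound 3 (0.07 log units; within the scatter)) that stays within the scatter, so the chloro and fluoro compounds cannot be told apart. Going by these compounds alone, the first direct comparison of fluoro with methoxy (step: a 1.6-fold higher number from compound 1 to compound 3 (0.20 log units; within the scatter)) also stays within the scatter, which means that methoxy, chloro and fluoro, each para to a large group on the shared core, now form a set of three whose numbers cannot be separated, rather than a single pair. No supporting measurement is available to explain why these three groups read alike.

Going by these compounds, what remains open is whether any group at this place can move the number beyond the scatter, as an amine, a carboxylic acid or a longer alkyl chain has no value here to show it. On these data alone, the other parts of the shared core are identical in all three compounds, so how much they matter for the number in this cell assay also remains unknown.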